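This account rests on a few compounds, and the source may have more. Where it says the series, first, only, none or still open, it means among the compounds named here.

Series notes. In a functional assay on PC-12 cells (Rattus norvegicus) for cytotoxicity, read by MTT assay, with stated times of 3 h and 2 h, tested at 10 uM (on this read-out lower numbers stand for a weaker effect and higher numbers for a stronger effect at the one concentration tested), compound 1 `O=C(CCCCC1CCSS1)NCc1cn(CCCOc2ccc3cc(-c4ccc(Cl)c(Cl)c4)c(=O)oc3c2)nn1` gives 49.6%. Compound 2 `CCOC(=O)c1cc2ccc(OCCCCCn3cc(CNC(=O)CCCCC4CCSS4)nn3)cc2oc1=O` stands lowest of the two numbers available: in this assay compound 2 gives 38.3%, which lies under the number for compound 1 by a margin beyond the usual scatter. Compound 3 `COc1ccc(-c2cc3ccc(OCCCCCn4cc(CNC(=O)CCCCC5CCSS5)nn4)cc3oc2=O)cc1` is not yet measured and differs from compound 2 by 4-methoxyphenyl in place of ethoxycarbonyl on an aromatic carbon. Among the compounds with values here, no step between two measured compounds covers this change, so the size of its effect is open. The step from compound 2 to compound 3 is expected to be a modest rise, a number 7.7 percentage points higher from compound 2 to compound 3 (within the scatter), though a change within the scatter remains possible. Compound 3 is estimated at 46%, with a range from 30% to 62%.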

Compound 3, a percentage reported as activity, at one concentration (the size of the read-out at that concentration, not a potency): 45.5%
Compound 3: the middle estimate sits 0.5 percentage points above what was measured, and the stated range covers the measured number.
By their numbers in this assay, from the lowest: compounds 2, 3 and 1 (each within the scatter of the next, the first and the last beyond it).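

At this position, on an aromatic carbon two atoms from the ring oxygen, 4-methoxyphenyl in place of ethoxycarbonyl gives a number 7.2 percentage points higher from compound 2 to compound 3 (within the scatter) in this assay. A group with a six-membered aromatic ring and a group with no ring are thus not told apart here by this read-out. No measurement at hand bears on the origin of this step. On these data alone, whether a carboxylic acid, an amine or a single methyl at this position would also stay within the scatter of compound 2 remains open.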